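Removing One Methoxy Group From a Dimethoxybenzyl Amine

This account rests on a few compounds, and the source may have more. Where it says the series, first, only, none or still open, it means among the compounds named here.

Measured so far:
In a functional assay on KM12 cells (Homo sapiens) for inhibition, read by sulforhodamine B assay, with a stated time of 48 h (on this read-out lower numbers stand for stronger inhibition of growth and higher numbers for weaker inhibition of growth), compound 1 `COc1ccc(CNc2nc3cc(N)cc(N)c3nc2-c2ccccc2)cc1OC` gives 13200 nM.
Compound 2 `COc1cc(CNc2nc3cc(N)cc(N)c3nc2-c2ccccc2)cc(OC)c1OC` gives 479 nM.
Compound 3 `CCOC(=O)[C@H](CCC(=O)O)NC(=O)c1ccc(Oc2nc3cc(N)cc(N)c3nc2-c2ccccc2)cc1` gives 27500 nM.

Compound 1 stands second highest of the three numbers: compound 3 gives a higher number, compound 2 a lower one. Compounds 1 and 2 share everything except one group on the benzyl ring, and there the step was a 28-fold lower number from compound 1 to compound 2 (1.44 log units; beyond the scatter), a large gain in growth inhibition from one extra methoxy group.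

Compound 4 `COc1ccc(CNc2nc3cc(N)cc(N)c3nc2-c2ccccc2)cc1` is compound 1 with a change in the same ring: hydrogen in place of methoxy on an aromatic carbon. Within the data shown here, the only measured step that bears on it is the one from compound 1 to compound 2, which runs the other way, adding a methoxy group rather than taking one away, and at another carbon of the ring. Adding a methoxy group helped greatly there, so taking one away from compound 1 is more likely to cost growth inhibition than to add to it, though the spot differs and the size is uncertain. Compound 4 is therefore expected to give a somewhat higher number, a step of a 1.7-fold higher number from compound 1 to compound 4 (0.22 log units; within the scatter). The estimate for compound 4 in this assay is 22000 nM, with a range from 7000 nM to 70000 nM.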

Compound 4, concentration for 50% growth inhibition: 13200 nM
Compound 4: middle estimate off by 1.7-fold (0.22 log units), on the high side; the range from low to high includes it.
By their numbers in this assay, from the lowest: compound 2; then compounds 1 and 4 (each within the scatter of the next); then compound 3.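

In this assay the change from 3,4-dimethoxyphenyl to 4-methoxyphenyl gives no change at the digits printed from compound 1 to compound 4 (within the scatter), so on this aromatic carbon, ortho to a methoxy group, hydrogen and methoxy cannot be told apart. Among these compounds, the only earlier step on this ring was a 28-fold lower number from compound 1 to compound 2 (1.44 log units; beyond the scatter), and set against it the new step shows that a methoxy group does not count the same on every carbon of the ring: it goes with a large change at the carbon of that step and with none that can be read at this one. Nothing measured here accounts for that contrast.

Hydrogen and methoxy are the only groups shown on this carbon, so it remains open whether a hydroxyl group, an ethoxy group or a fluorine atom there would also leave the number where it is. Going by these compounds, it is also open whether this carbon would matter as little in compound 2, where the ring carries a further methoxy group.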